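Methyl groups on a shared core in prostate cancer cells

The source may hold more compounds than are shown below. What is called first, only, known or untested is meant among the compounds shown, and "the series" means these compounds.

Compound 1 `CS(=O)(=O)c1ccc(Nc2ncc(F)c(Nc3nc4ccccc4s3)n2)cc1` is tested in a functional assay on PC-3 cells (Homo sapiens) for antiproliferative activity, read by MTT assay, with a stated time of 48 h (on this read-out lower numbers stand for stronger inhibition and higher numbers for weaker inhibition), where compound 1 gives 2830 nM. Compound 2 `Cc1ccc2nc(Nc3nc(Nc4ccc(S(C)(=O)=O)cc4)ncc3F)sc2c1` differs from it by methyl in place of hydrogen on an aromatic carbon. In this assay compound 2 reaches only a limit of the assay, > 50000 nM. That is the step of an at least 17-fold higher number from compound 1 to compound 2 (1.24 log units; beyond the scatter), a loss described by the limit of > 50000 nM in this assay, at which 1 of the 3 values shown sits. Compound 3 `CS(=O)(=O)c1ccc(Nc2nccc(Nc3nc4ccc(F)cc4s3)n2)cc1` shares the atoms of compound 1, joined differently; the difference between the two cores is not broken down here. In this assay compound 3 gives 1940 nM. Compound 4 `Cc1cnc(Nc2ccc(S(C)(=O)=O)cc2)nc1Nc1nc2ccc(F)cc2s1` carries the same kind of change, (methyl in place of hydrogen on an aromatic carbon), but at a different place: on a six-membered aromatic ring with 2 nitrogen, ortho and para to a large group, rather than on a six-membered aromatic ring of carbon only in a fused system. Compound 4 is expected to show a 7.7-fold higher number from compound 3 to compound 4 (0.89 log units; beyond the scatter), a loss that rests on compound 1 and compound 2 and their step of an at least 17-fold higher number from compound 1 to compound 2 (1.24 log units; beyond the scatter). Compound 4 is estimated at 15000 nM, between 3000 nM and 50000 nM.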

Compound 4, half-maximal inhibitory concentration: > 50000 nM
Compound 4: only a limit was reported; the forecaster's own chance of this, stated with the estimate: 30%; middle value at least 3.3-fold (0.52 log units) from the limit.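

In this assay the new step is an at least 25-fold higher number from compound 3 to compound 4 (1.41 log units; beyond the scatter) for methyl in place of hydrogen on an aromatic carbon, so the change goes with a large loss on both cores shown, though at a different place on each. Compound 4 gives > 50000 nM as a limit of the assay, not a number. The direction of the change therefore carries over between these two cores, but its size cannot be compared: the same change on two cores in this assay, an at least 17-fold higher number (1.24 log units; beyond the scatter) from compound 1 to compound 2 and an at least 25-fold higher number (1.41 log units; beyond the scatter) from compound 3 to compound 4; the limit leaves it open whether they differ

The compounds shown leave open whether a methoxy group or an amine at these places would behave as methyl does. They also leave open whether the loss holds on any further core.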